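From difluorobenzyl to bromobenzyl on the sulfur

The source may hold more compounds than are shown below. What is called first, only, known or untested is meant among the compounds shown, and "the series" means these compounds.

Compound 1 `Sc1nnc(-c2ccc3c(c2)OCCO3)n1-c1ccccc1` gives 47000 nM
Compound 2 `Fc1cccc(F)c1CSc1nnc(-c2ccc3c(c2)OCCO3)n1-c1ccccc1` gives 84200 nM

For the measured compounds named here, in a functional assay on BGC-823 cells (Homo sapiens) for antiproliferative activity, read by MTT assay, with a stated time of 24 h (on this read-out lower numbers stand for stronger inhibition and higher numbers for weaker inhibition), compound 2 gives 84200 nM and sits within the scatter of compound 1, the only other compound measured. Compound 3 `Brc1ccccc1CSc1nnc(-c2ccc3c(c2)OCCO3)n1-c1ccccc1` differs from compound 2 by 2-bromophenyl in place of 2,6-difluorophenyl on a saturated chain carbon bound to a sulfur and so has 2-bromophenyl in place of 2,6-difluorophenyl on a saturated chain carbon bound to a sulfur. Given a 1.8-fold higher number from compound 1 to compound 2 (0.25 log units; within the scatter) for 2,6-difluorobenzyl in place of hydrogen on a sulfur, the only measured step that bears on this, no step beyond the scatter is expected in this assay for compound 3. The expected size is a 1.2-fold lower number from compound 2 to compound 3 (0.08 log units; within the scatter) as an estimate. Compound 3 is expected at 70000 nM with 30000 nM to 160000 nM as its estimated range.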

Compound 3, half-maximal inhibitory concentration: > 100000 nM
Compound 3: only a limit was reported; the forecaster's own chance of this, stated with the estimate: 10%; middle value at least 1.4-fold (0.15 log units) from the limit.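

In this assay compound 3 is reported only as a limit: the limit of > 100000 nM in this assay, at which 1 of the 3 values shown sits.

Even so, it gives the first step beyond the scatter at this sulfur, an at least 2.1-fold higher number from compound 1 to compound 3 (0.32 log units; beyond the scatter), which 2,6-difluorobenzyl did not. The exchange of the two aromatic groups is less clear, an at least 1.1-fold higher number from compound 2 to compound 3 (0.07 log units; that floor lies within the scatter), so this floor does not separate 2-bromobenzyl from 2,6-difluorobenzyl.

On these data alone, how far compound 3 lies past its limit stays unknown, and so does the full size of both steps. As far as these compounds go, whether an amine, a carboxylic acid or a longer chain in place of 2-bromobenzyl on the sulfur would give a lower number also remains open.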